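One Aromatic Group Exchanged in a Small Series

The compounds below may be only part of what the source reports. "The series", "measured", "known", "first", "only" and "open" are said of these compounds alone.

Within the data shown here, two related compounds have numbers so far in a functional assay on MCF7 cells (Homo sapiens) for inhibition, read by MTT assay, with a stated time of 72 h; a higher number here means a weaker inhibitor, a lower number a stronger inhibitor. Here compound 1 (`COc1cc2c(Oc3ccc(NC(=O)c4nn(-c5ccccc5C(F)(F)F)ccc4=O)cc3)ccnc2cc1OCC(=O)NO`) gives 6320 nM and compound 2 (`COc1cc2c(Oc3ccc(NC(=O)c4nn(-c5ccc(Cl)c(C(F)(F)F)c5)cc(C)c4=O)cc3)ccnc2cc1OCC(=O)NO`) gives 3480 nM, so compound 2 stands within the usual scatter of compound 1 and neither can be called the better inhibitor. Compound 3 (`COc1cc2c(Oc3ccc(NC(=O)c4nn(-c5ccccc5C)cc(C)c4=O)cc3)ccnc2cc1OCC(=O)NO`) has not yet been measured. It keeps the rest of compound 2 but carries 2-methylphenyl in place of 4-chloro-3-(trifluoromethyl)phenyl on an aromatic nitrogen. Among the measured compounds shown here, no measured pair isolates this exchange, so its effect cannot be read directly. The two measured compounds differ in more than one place yet stay within the scatter, so no step beyond the scatter is expected in this assay. The estimated change is a 1.3-fold higher number from compound 2 to compound 3 (0.11 log units; within the scatter). For compound 3 the estimated value is 4500 nM, with an expected range from 1800 nM to 11000 nM.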

Compound 3, half-maximal inhibitory concentration: 8780 nM
The estimate for compound 3 lay 2.0-fold (0.29 log units) below the measured number; the measured number falls inside the stated range.
By their numbers in this assay, from the lowest: compounds 2, 1 and 3 (each within the scatter of the next, the first and the last beyond it).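

In this assay, among these compounds, the exchange of 4-chloro-3-(trifluoromethyl)phenyl for 2-methylphenyl on the aromatic nitrogen gives a 2.5-fold higher number from compound 2 to compound 3 (0.40 log units; beyond the scatter) and is the first comparison here that changes only one place. It shows that the group at this position can move the number beyond the scatter, if only modestly, with the weaker inhibitor carrying the group with fewer heavy atoms. Nothing measured here gives a reason for the step.

The exchange removes the chlorine and the trifluoromethyl and adds a methyl all at once, so this one pair cannot show which of these changes matters. On these data alone, how a plain phenyl, a 4-chlorophenyl or a phenyl bearing a methoxy group would compare at this position remains open.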